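The source may hold more compounds than are shown below. What is called first, only, known or untested is meant among the compounds shown, and "the series" means these compounds.

Compound 1 `Cc1cc(=O)n2nc(SCc3ccc(C(C)C)cc3)nc2[nH]1`: 35200 nM
Compound 2 `Cc1cc(O)n2nc(SCc3cccc(Cl)c3)nc2n1`: > 80000 nM (a limit of the assay)

Of the compounds shown here, two have been tested so far in a functional assay on A549 cells (Homo sapiens) for antiproliferative activity, read by MTT assay, with a stated time of 24 h; a higher number here means a weaker inhibitor, a lower number a stronger inhibitor. Within the data shown here, compound 1 gives 35200 nM, the only actual number available. Compound 2 is recorded at > 80000 nM, which is a limit and not a number. That leaves a single reference point, alongside (the limit of > 80000 nM in this assay, at which 1 of the 2 values shown sits).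

The next compound to be tested is compound 3 `Cc1cc(=O)n2nc(SCc3ccc([N+](=O)[O-])cc3)nc2[nH]1`, which keeps the core of compound 1 and changes only one substituent. It has nitro in place of isopropyl on an aromatic carbon, para to a large group (nitro in place of isopropyl on an aromatic carbon). Among the measured compounds shown here, no step between measured compounds shows what such an exchange does, so the expectation rests on compound 1 at 35200 nM. In this assay, no step beyond the usual scatter is expected, with only a slight lean towards weaker inhibition and a real chance that compound 3 also ends at a limit. The estimate amounts to an expected 1.2-fold higher number from compound 1 to compound 3 (0.08 log units; within the scatter). For compound 3 the expected value is 42000 nM, with an estimated range of 14000 nM to 80000 nM.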

Compound 3, half-maximal inhibitory concentration: > 80000 nM
Compound 3 was reported as a limit; the forecaster's own chance of this, stated with the estimate: 25%; middle value at least 1.9-fold (0.27 log units) from the limit.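

In this assay, the exchange of isopropyl for nitro on this aromatic carbon, para to a large group, gives an at least 2.2-fold higher number from compound 1 to compound 3 (0.35 log units; beyond the scatter). Among these compounds, this is the first step that can be read, and it shows that the substituent at this position matters: two groups with the same count of heavy atoms, differing in their atoms and in the hydrogen-bond acceptors that nitro brings, do not give an equivalent result, although these two compounds alone cannot show which difference counts. The value of compound 3, > 80000 nM, is a limit of the assay and not a number, so the step gives only a minimum size, and compound 1 remains the sole compound with an actual number: the limit of > 80000 nM in this assay, at which 2 of the 3 values shown sit.

The compounds shown leave open whether any other group at this position, such as an amine, a methoxy group or a longer alkyl chain, would give a stronger inhibitor than compound 1 or would also end at the limit. They also leave open whether isopropyl itself contributes to the measurable activity of compound 1 or whether nitro alone accounts for the loss.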